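Cytotoxicity notes: amide side chain in place of fluoro

The compounds below may be only part of what the source reports. "The series", "measured", "known", "first", "only" and "open" are said of these compounds alone.

The three measured compounds share one core. Compound 1 `O=C(CN1CCCCC1)Nc1ccc(-c2nc3cc(C(F)(F)F)ccc3[nH]2)cc1` in an ADME assay on MT4 cells (Homo sapiens) for cytotoxicity, read by MTT assay, with a stated time of 96 h (a lower number here means that less compound is tolerated, a higher number that more compound is tolerated), gives 6000 nM. Compound 2 `Fc1ccc(-c2nc3cc(C(F)(F)F)ccc3[nH]2)cc1` in this assay gives 22000 nM, the highest of the three numbers, beyond the scatter from compound 1 and further still from compound 3. Compound 3 `COc1ccc(-c2nc3cc(Cl)c(Cl)cc3[nH]2)c(N)c1` in this assay gives 3000 nM, the lowest of the three.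

Compound 4 `O=C(CN1CCCC1)Nc1ccc(-c2nc3cc(C(F)(F)F)ccc3[nH]2)cc1` is not yet measured. It differs from compound 2 in one place: (((pyrrolidin-1-yl)methyl)carbonyl)amino in place of fluoro on an aromatic carbon. The entering group sits para to a large group and brings one five-membered non-aromatic ring with one hetero atom, one hydrogen-bond donor and two hydrogen-bond acceptors. Among the compounds with values here, no measured pair makes this exact step, so the direction rests on compound 1, whose side chain is the closest relative of the entering group and which gives 6000 nM, clearly under compound 2. A downward step beyond the scatter is expected, estimated as a 3.7-fold lower number from compound 2 to compound 4 (0.56 log units; beyond the scatter). Compound 4 is expected to give 6000 nM in this assay, with a range from 2500 nM to 15000 nM.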

Compound 4, half-maximal cytotoxic concentration: 18000 nM
Compound 4: middle estimate off by 3.0-fold (0.48 log units), on the low side; measured number outside the range, above it.
By their numbers in this assay, from the lowest: compounds 3 and 1 (each within the scatter of the next); then compounds 4 and 2 (each within the scatter of the next).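

In this assay, (((pyrrolidin-1-yl)methyl)carbonyl)amino in place of fluoro on the aromatic carbon gives a 1.2-fold lower number from compound 2 to compound 4 (0.09 log units; within the scatter) and so shows that this position takes the entering group without a step beyond the scatter. The step beyond the scatter lies within the side chain itself: pyrrolidin-1-yl in place of piperidin-1-yl on the saturated chain carbon gives a 3.0-fold higher number from compound 1 to compound 4 (0.48 log units; beyond the scatter) and shows that the number in this series depends on the ring at the end of the amide side chain, not only on the presence of that chain.

As far as these compounds go, whether other amines, such as morpholine or an open-chain dimethylamino group, follow compound 4 or compound 1 remains open. So does the effect of a longer chain between the carbonyl and the ring.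

No measurement on these compounds accounts for the difference between the two rings.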